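A few compounds are considered here, and "the series" means these few. Any claim that something is new, unique, unknown or untested is made for them only; others in the source may bear on it.

In a functional assay on MCF7 cells (Homo sapiens) for cytotoxicity, read by MTT assay, with a stated time of 72 h (on this read-out lower numbers stand for stronger inhibition and higher numbers for weaker inhibition), compound 1 `COc1cc2ncnc(Nc3ccc(F)c(Cl)c3)c2cc1NC(=O)N/N=C/c1cccc(Br)c1` gives 27100 nM and compound 3 `COc1cc2ncnc(Nc3ccc(F)c(Cl)c3)c2cc1NC(=O)N/N=C/c1ccc([N+](=O)[O-])cc1` gives 36800 nM. For compound 2 `COc1cc2ncnc(Nc3ccc(F)c(Cl)c3)c2cc1NC(=O)N/N=C/c1ccc(C#N)cc1` the record reads "not determined" (no result reported), so it adds nothing to the comparison. Compound 3 therefore has one measured neighbour, compound 1, and the two lie within the scatter of each other. Compound 4 `COc1ccc(/C=N/NC(=O)Nc2cc3c(Nc4ccc(F)c(Cl)c4)ncnc3cc2OC)cc1` has methoxy in place of nitro on an aromatic carbon, para to a large group: methoxy in place of nitro on an aromatic carbon. Going by the values given here, no measured compound carries methoxy, so the change has not been tested directly. Among the compounds with values here, the only measured step, a 1.4-fold higher number from compound 1 to compound 3 (0.13 log units; within the scatter), falls at the same end of the molecule and bears on the change only indirectly. Within the data shown here, with that small step as the sole guide, no shift beyond the scatter is expected in this assay, and neither direction is favoured. The estimated step is a 1.2-fold lower number from compound 3 to compound 4 (0.09 log units; within the scatter), which is expected to stay small. For compound 4 the expected value is 30000 nM, with an estimated range from 12000 nM to 70000 nM.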

Compound 4, half-maximal inhibitory concentration: 8140 nM
Compound 4: the middle estimate sits 3.7-fold (0.57 log units) above what was measured, outside the stated range (below it).
By their numbers in this assay, from the lowest: compound 4; then compounds 1 and 3 (each within the scatter of the next).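

In this assay the group on the aromatic carbon para to a large group proves able to move the number beyond the scatter: methoxy in place of nitro gives a 4.5-fold lower number from compound 3 to compound 4 (0.66 log units; beyond the scatter), whereas the earlier step, a 1.4-fold higher number from compound 1 to compound 3 (0.13 log units; within the scatter), did not separate its two compounds. The 4-methoxyphenyl compound also stands apart from the 3-bromophenyl one, with a 3.3-fold lower number from compound 1 to compound 4 (0.52 log units; beyond the scatter), so compound 4 has the lowest number of the three with values. Nothing given here accounts for this difference.

Whether the lower number is particular to methoxy remains open, as other groups on this carbon, such as an amine, a hydroxyl or a longer ethoxy chain, are not among the compounds shown. On these data alone, it is also open whether the step would hold on any other cell line.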